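Cyclopropyl in place of ethyl: expected cytotoxicity

The source may hold more compounds than are shown below. What is called first, only, known or untested is meant among the compounds shown, and "the series" means these compounds.

Compound 1, `COc1cc(-c2ccccc2)nc(-n2nc(C)cc2C)n1`: in an ADME assay on CHO cells (Cricetulus griseus) for cytotoxicity, read by MTT assay (a higher number here means a weaker inhibitor, a lower number a stronger inhibitor), compound 1 gives > 50000 nM, which is a limit of the assay rather than a number.
Compound 2, `Cc1cc(C)n(-c2nc(C(F)(F)F)cc(=O)[nH]2)n1`: in this assay compound 2 gives 150000 nM.
Compound 3, `CCc1cc(C)nn1-c1nc(C(F)(F)F)cc(=O)[nH]1`: in this assay compound 3 gives 108000 nM.

Compound 3 holds the lowest of the two numbers; compound 2 stands nearest, and the step of a 1.4-fold lower number from compound 2 to compound 3 (0.14 log units; within the scatter) lies within the scatter. Compound 4, `Cc1cc(C2CC2)n(-c2nc(C(F)(F)F)cc(=O)[nH]2)n1`, differs from compound 3 by cyclopropyl in place of ethyl on an aromatic carbon. Within the data shown here, the only measured step that touches this part of the molecule is a 1.4-fold lower number from compound 2 to compound 3 (0.14 log units; within the scatter), a change too small to stand out. On that basis the expected step of a 1.1-fold lower number from compound 3 to compound 4 (0.03 log units; within the scatter) is no larger than the scatter. Compound 4 is therefore expected to give about 100000 nM in this assay, within 40000 nM to 250000 nM.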

Compound 4, half-maximal inhibitory concentration: 78000 nM
For compound 4 the middle estimate is 1.3-fold (0.11 log units) above the measured one; the measured number falls inside the stated range.
By their numbers in this assay, from the lowest: compounds 4, 3 and 2 (each within the scatter of the next).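

At this aromatic carbon, a three-membered ring can stand in place of the open ethyl chain in this assay without a step beyond the scatter: a 1.4-fold lower number from compound 3 to compound 4 (0.14 log units; within the scatter). Cyclopropyl in place of methyl also stays inside it: a 1.9-fold lower number from compound 2 to compound 4 (0.28 log units; within the scatter). Methyl, ethyl and cyclopropyl at this carbon therefore cannot be told apart by these numbers.

As far as these compounds go, whether an amine or a carboxylic acid at this carbon would move the number beyond the scatter stays open. No measurement shown bears on why these three groups read alike.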